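Substituent on the saturated carbon bound to the aromatic nitrogen

The compounds below may be only part of what the source reports. "The series", "measured", "known", "first", "only" and "open" are said of these compounds alone.

Two analogues share the core and differ only in the group carried on the saturated chain carbon bound to an aromatic nitrogen. Compound 1 `CNc1ncc2c(-c3ccc(N4CCNCC4)nc3)nn(CC3CCCC3)c2n1` gives 120 nM in an assay for inhibition of tyrosine-protein kinase receptor UFO (Homo sapiens), read by 33P incorporation, in the presence of a further agent that is not named here; a lower number here means a stronger inhibitor, a higher number a weaker inhibitor. Compound 2 `CNc1ncc2c(-c3ccc(N4CCNCC4)nc3)nn(CC3OCCO3)c2n1` gives 530 nM in this assay, the highest of the two numbers; the step of a 4.4-fold higher number from compound 1 to compound 2 (0.65 log units; beyond the scatter) separates it from compound 1.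

Compound 3 `CNc1ncc2c(-c3ccc(N4CCNCC4)nc3)nn(Cc3cn(Cc4ccccc4)nn3)c2n1` is the next analogue, not yet measured. It differs from compound 2 as follows: 1-benzyl-1H-1,2,3-triazol-4-yl in place of 1,3-dioxolan-2-yl on a saturated chain carbon bound to an aromatic nitrogen. Among the compounds with values here, only the single measured step at this position bears on the change, and it shows that exchanging the group there moves the number by a modest amount, in the direction seen from compound 1 to compound 2. Within the data shown here, no measured pair tells how an aromatic group of this size behaves here. The step of a 1.8-fold lower number from compound 2 to compound 3 (0.25 log units; within the scatter) is therefore expected to stay within the scatter, with a wide range either way. Compound 3 is estimated at 300 nM, between 80 nM and 1500 nM.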

Compound 3, half-maximal inhibitory concentration: 400 nM
Compound 3: middle estimate off by 1.3-fold (0.12 log units), on the low side, within the range that was stated.
By their numbers in this assay, from the lowest: compound 1; then compounds 3 and 2 (each within the scatter of the next).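

In this assay, 1-benzyl-1H-1,2,3-triazol-4-yl in place of 1,3-dioxolan-2-yl gives a 1.3-fold lower number from compound 2 to compound 3 (0.12 log units; within the scatter), so at this position a group with two aromatic rings cannot be told apart from a single non-aromatic ring carrying two oxygens. In place of cyclopentyl, the same group gives a 3.3-fold higher number from compound 1 to compound 3 (0.52 log units; beyond the scatter), which leaves compound 1 the strongest inhibitor of the three and puts both hetero-atom-containing groups on the weaker side of cyclopentyl. No supporting data accompany these results to explain them.

On these data alone, whether the edge of compound 1 belongs to a saturated carbon ring in general remains open, as cyclohexyl, phenyl or a longer alkyl chain at this place could test. As far as these compounds go, how an amine or a carboxylic acid on the chain carbon would read is also open.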